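The source may report more compounds than this note shows. Statements on the series, on what has been measured and on what is new or still open speak of the compounds shown alone.

Compound 1, `Oc1c(C(Nc2ccccc2)c2ccccc2)ccc2ccccc12`, is the starting point. In an assay on isolated protein for inhibition of CAAX prenyl protease 2 (Homo sapiens), with stated times of 60 s and 60 min (a lower number here means a stronger inhibitor, a higher number a weaker inhibitor), compound 1 gives 4900 nM, the second highest of the three numbers recorded so far. Its closest neighbour is compound 3, `Oc1c(C(Nc2ccccc2)c2ccccc2)cc(Br)c2ccccc12`, which gives 5400 nM; the step of a 1.1-fold higher number from compound 1 to compound 3 (0.04 log units; within the scatter) is a bromine added to the shared core. Furthest away is compound 2, `O=C(O)c1ccc(NC(c2ccccc2)c2ccc3ccccc3c2O)cc1`, with 4200 nM; the step of a 1.2-fold lower number from compound 1 to compound 2 (0.07 log units; within the scatter) is a carboxy group added to the aniline ring. Both steps, then, change a ring other than the one at issue here and both stay within the scatter.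

The new compound 4, `Oc1c(C(Nc2ccccc2)c2c(F)cc(Br)cc2F)ccc2ccccc12`, differs from compound 1 by 4-bromo-2,6-difluorophenyl in place of phenyl on a saturated chain carbon bound to an aromatic carbon and a nitrogen on an aromatic ring. Going by the values given here, no measured step touches this phenyl, so the only guidance is that the two substitutions made elsewhere, bromine in compound 3 and carboxy in compound 2, left this assay essentially unchanged. The expected step of a 1.2-fold lower number from compound 1 to compound 4 (0.09 log units; within the scatter) is therefore small, without a clear direction beyond the scatter. Compound 4 is estimated at 4000 nM, within a range from 1500 nM to 11000 nM.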

Compound 4, half-maximal inhibitory concentration: 9400 nM
For compound 4 the middle estimate is 2.4-fold (0.37 log units) below the measured one, within the range that was stated.
By their numbers in this assay, from the lowest: compounds 2, 1, 3 and 4 (each within the scatter of the next, the first and the last beyond it).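

Among the compounds shown, only compound 4 alters the phenyl on the saturated chain carbon, and in this assay the change to 4-bromo-2,6-difluorophenyl gives a step (a 1.9-fold higher number from compound 1 to compound 4 (0.28 log units; within the scatter)) that stays within the scatter. This position therefore accepts a ring carrying fluorine and bromine without a change that can be told from repeat-measurement noise, as with the bromo and carboxy changes made elsewhere on compound 1. No evidence is at hand that bears on this result.

Fluorine and bromine enter together in compound 4, so the effect of each alone stays open. Also open, going by these compounds, is what this position would do with a ring bearing an amine or a carboxylic acid, or with a longer chain in place of the phenyl.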